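Sec-butyl for butyl on an imidazole-type chain

A few compounds are considered here, and "the series" means these few. Any claim that something is new, unique, unknown or untested is made for them only; others in the source may bear on it.

Measured so far in a functional assay on PC-3 cells (Homo sapiens) for cytotoxicity, read by WST assay, with a stated time of 3 days; a lower number here means a stronger inhibitor, a higher number a weaker inhibitor:

Compound 1 `Cn1ccnc1/C=C/C(=O)/C=C/c1coc2ccccc2c1=O` gives 2800 nM
Compound 2 `CCCCn1ccnc1/C=C/C(=O)/C=C/c1coc2ccccc2c1=O` gives 2000 nM

Compound 2 stands within the scatter of compound 1, so these numbers cannot rank the two. Compound 3 (`CCC(C)n1ccnc1/C=C/C(=O)/C=C/c1coc2ccccc2c1=O`) carries sec-butyl in place of butyl on an aromatic nitrogen. Going by the values given here, no measured compound carries sec-butyl. Among the compounds with values here, only one measured step bears on this change, a 1.4-fold lower number from compound 1 to compound 2 (0.15 log units; within the scatter) in the chain on that nitrogen, so no step beyond the scatter is expected in this assay here. The step expected is a 1.2-fold higher number from compound 2 to compound 3 (0.06 log units; within the scatter) as an estimate only. Compound 3 is expected at 2300 nM with an estimated range from 1000 nM to 5000 nM.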

Compound 3, half-maximal inhibitory concentration: 1800 nM
For compound 3 the middle estimate is 1.3-fold (0.11 log units) above the measured one; the range from low to high includes it.
By their numbers in this assay, from the lowest: compounds 3, 2 and 1 (each within the scatter of the next).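

In this assay, sec-butyl in place of butyl gives a 1.1-fold lower number from compound 2 to compound 3 (0.05 log units; within the scatter) and sec-butyl in place of methyl gives a 1.6-fold lower number from compound 1 to compound 3 (0.19 log units; within the scatter). Branching the chain on this aromatic nitrogen therefore gives no readable change, and methyl, butyl and sec-butyl cannot be ranked here. Nothing available offers an explanation for these results. Still open, on these data alone, is whether a longer chain such as octyl, a phenyl ring, an amine or a carboxylic acid on this nitrogen would move the number beyond the scatter.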